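From 4-methoxyphenyl to 4-bromophenyl: an open step

This account rests on a few compounds, and the source may have more. Where it says the series, first, only, none or still open, it means among the compounds named here.

Compound 1 `C=CCc1cc(O)c(O)c(CN2CCC(CCO)CC2)c1`: 2%
Compound 2 `C=CCc1ccc(OCc2cn(-c3cc(OC)c(OC)c(OC)c3)nn2)c(O)c1`: 2.5%
Compound 3 `C=CCc1ccc(OCc2cn(-c3ccc(OC)cc3)nn2)c(O)c1`: 49.9%

Of the compounds shown here, three have been tested in a functional assay on HepG2 cells (Homo sapiens) for inhibition, read by MTT assay, with a stated time of 72 h, tested at 50 uM; a higher number here means more inhibition of growth at the concentration tested, a lower number less inhibition of growth. Among them, compound 3 gives 49.9%, the highest of the three numbers, and its gaps to both compound 2 and compound 1 lie beyond the scatter.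

The next compound to be tested is compound 4 `C=CCc1ccc(OCc2cn(-c3ccc(Br)cc3)nn2)c(O)c1`. It differs from compound 3 in one place, with bromo in place of methoxy on an aromatic carbon, para to a large group, so that 4-methoxyphenyl becomes 4-bromophenyl (bromo in place of methoxy on an aromatic carbon).

Among the measured compounds shown here, no pair of measured compounds differs in one place, so the data give no direct guide to this change. The expectation therefore starts from compound 3 at 49.9%, and the range is kept wide. An estimated a number 4.9 percentage points lower from compound 3 to compound 4 (within the scatter) is expected, which would be no step beyond the scatter. For compound 4 the expected value in this assay is 45%, with an estimated range from 20% to 70%.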

Compound 4, percent growth inhibition at one concentration: 9.5%
Estimate against measurement, compound 4: 35.5 percentage points above; measured number outside the range, below it.
By their numbers in this assay, from the lowest: compounds 1, 2 and 4 (each within the scatter of the next); then compound 3.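

In this assay, among the compounds shown here, the exchange of methoxy for bromo gives a number 40.4 percentage points lower from compound 3 to compound 4 (beyond the scatter), the first comparison in this set between compounds that differ in one place. It shows that growth inhibition at the concentration tested can shift sharply with a single exchange on this aromatic carbon, para to a large group, while the rest of the structure stays the same. No supporting data bear on why this exchange has so large an effect.

The compounds shown leave open whether the step reflects the loss of methoxy, the arrival of bromo, or both. Chloro, ethoxy or a carboxylic acid on the same carbon would help separate these readings, as would a second pair carrying the same exchange on a different core.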